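Methoxy removal on the benzamide ring of compound 1

The source may report more compounds than this note shows. Statements on the series, on what has been measured and on what is new or still open speak of the compounds shown alone.

Measured compounds:
compound 1 `COc1cc(Cl)c(C(=O)NC(=O)Nc2nc3ccc(S(=O)(=O)CCCN4CCN(C)CC4)cc3s2)cc1-n1cccn1` — 2.2
compound 2 `CS(=O)(=O)c1ccc2nc(NC(=O)NC(=O)c3ccccc3Cl)sc2c1` — 2.5
compound 3 `CCN(CC)CCCS(=O)(=O)c1ccc2nc(NC(=O)NC(=O)c3ccccc3Cl)sc2c1` — 1.7

The read-out throughout is a physicochemical assay for lipophilicity; a higher number here means a more lipophilic compound, a lower number a more polar compound. Compound 1 stands second of the three numbers: its value lies within the scatter of compound 2, and beyond the scatter above compound 3. Within the data shown here, the one step available, a number 0.80 log units lower from compound 2 to compound 3 (beyond the scatter), is modest and concerns the chain on the sulfonyl sulfur, not the aromatic ring of the acyl part.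

Compound 4 `CN1CCN(CCCS(=O)(=O)c2ccc3nc(NC(=O)NC(=O)c4cc(-n5cccn5)ccc4Cl)sc3c2)CC1` differs from compound 1 in one place: hydrogen in place of methoxy on an aromatic carbon. Among the measured compounds shown here, no measured pair in this set differs by a methoxy group on an aromatic carbon, so the step from compound 2 to compound 3 does not bear directly on it; it shows only that a change elsewhere in the shared core moves this assay by a modest amount. With nothing measured for the methoxy itself, the expectation is a step no larger than the usual scatter, in no fixed direction.

Compound 4 is therefore estimated at 2.2, between 1.8 and 2.6, which corresponds to an expected step of no change at the digits printed from compound 1 to compound 4 (within the scatter).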

Compound 4, distribution coefficient: 2
Estimate against measurement, compound 4: 0.20 log units above; the range from low to high includes it.
By their numbers in this assay, from the lowest: compounds 3, 4, 1 and 2 (each within the scatter of the next, the first and the last beyond it).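

Among these compounds, replacing methoxy with hydrogen on the aromatic carbon ortho to a 1H-pyrazol-1-yl group gives the first measured pair at this position, and in this assay the step is a number 0.20 log units lower from compound 1 to compound 4 (within the scatter). Taking away the methoxy, with its 2 heavy atoms and 1 hydrogen-bond acceptor, therefore leaves compound 4 not separated from compound 1 in this read-out, whereas the only earlier step, a number 0.80 log units lower from compound 2 to compound 3 (beyond the scatter), lay on the chain on the sulfonyl sulfur, not on the aromatic ring of the acyl part. Nothing measured here bears on why the read-out responds to this change as it does.

Going by these compounds, whether other groups on this aromatic carbon, such as ethoxy, a primary amine or a carboxylic acid, would also stay within the scatter of compound 4 remains open. Also open, on these data alone, is whether methoxy on this carbon would give a similar step without the 1H-pyrazol-1-yl group, which compound 2 and compound 3 do not carry, or with a different chain on the sulfonyl sulfur.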